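Chloro in place of methyl: what to expect for compound 4

The compounds below may be only part of what the source reports. "The series", "measured", "known", "first", "only" and "open" are said of these compounds alone.

Compound 1 `O=C(/C=C\c1ccccc1)N1N=C(c2ccncc2)OC1c1c[nH]c2ccccc12` in an ADME assay on A549 cells (Homo sapiens) for cytotoxicity, read by MTT assay, with a stated time of 48 h; a lower number here means a stronger inhibitor of growth, a higher number a weaker inhibitor of growth: > 30 ug/mL, a limit of the assay.
Compound 2 `Cc1ccc(/C=C\C(=O)N2N=C(c3ccncc3)OC2c2c[nH]c3ccccc23)cc1` in this assay: > 30 ug/mL, a limit of the assay.
Compound 3 `O=C(/C=C\c1ccccc1F)N1N=C(c2ccncc2)OC1c1c[nH]c2ccccc12` in this assay: > 30 ug/mL, a limit of the assay.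

Compound 2 stands at the limit of > 30 ug/mL in this assay, at which 3 of the 3 values shown sit, so its position is only a limit, not a number. Compound 4 `O=C(/C=C\c1ccc(Cl)cc1)N1N=C(c2ccncc2)OC1c1c[nH]c2ccccc12` differs from compound 2 by chloro in place of methyl on an aromatic carbon. The measured steps that bear on this change are a step that the two limits leave unreadable from compound 1 to compound 2 and a step that the two limits leave unreadable from compound 2 to compound 3, and both are unreadable, since each end sits at the limit. Compound 4 is therefore expected to give a step that the limit leaves unreadable from compound 2 to compound 4 in this assay, meaning no readable step. Compound 4 is estimated at 40 ug/mL, with a range from 15 ug/mL to 100 ug/mL, most likely reported as a limit again.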

Compound 4, concentration for 50% growth inhibition: > 30 ug/mL
Compound 4 ended at the assay's limit; the forecaster's own chance of this, stated with the estimate: 80%; the middle value does not contradict the limit.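

Compound 4, like compound 1, compound 2 and compound 3, gives only a limit in this assay, not a number, so no step among these four compounds can be read: the limit of > 30 ug/mL in this assay, at which 4 of the 4 values shown sit.

The compounds shown leave open how strongly any of the four inhibits growth, and whether hydrogen, methyl, fluoro or chloro on the aromatic carbon makes any difference.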